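Swapping the tail group on a flexible chain

The compounds below may be only part of what the source reports. "The series", "measured", "known", "first", "only" and "open" are said of these compounds alone.

Three compounds share a core and differ only in the group hanging from an amine nitrogen at the end of a saturated chain. In a functional assay on the whole organism with Rattus norvegicus as the target, at a dose of 100 mg/kg (on this read-out lower numbers stand for less inhibition and higher numbers for more inhibition at the one dose given (going by the name of the read-out)), compound 1 `C/N=C(/NC#N)NCCCCCn1nc(-c2ccccc2)ccc1=O` gives 47.6%, compound 2 `O=c1ccc(-c2ccccc2)nn1CCCCNC(=S)Nc1ccccc1` gives 38.4%, and compound 3 `CCC/N=C(/NC#N)NCCCCn1nc(-c2ccccc2)ccc1=O` gives 26.3%. Compound 3 thus stands lowest of the three: compound 2 sits nearest, and compound 1 furthest above it, both gaps lying beyond the scatter.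

The next compound, compound 4 `C/N=C(\S)NCCCCn1nc(-c2ccccc2)ccc1=O`, is made from compound 3 by a group of 4 heavy atoms (2 carbon, 1 nitrogen, 1 sulfur; no ring) in place of a group of 8 heavy atoms (5 carbon, 3 nitrogen; no ring), on an amine nitrogen.

The step that bears on this is the one already seen: a number 12.1 percentage points lower from compound 2 to compound 3 (beyond the scatter), where a group holding sulfur gave way to a group holding three nitrogens and a triple bond. Compound 4 moves back toward a sulfur-bearing group, though a far smaller one than in compound 2, so a partial reversal of that loss is expected rather than a full one. Compound 1 and compound 3 differ in two places at once, so their gap says nothing direct about this change.

For compound 4 the expected step is a number 11.7 percentage points higher from compound 3 to compound 4 (beyond the scatter), placing the estimate at 38%, with a plausible range from 22% to 54%.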

Compound 4, a percentage reported as inhibition, in the whole organism at one dose (the size of the read-out at that dose, not a potency): 87.1%
Compound 4: middle estimate off by 49.1 percentage points, on the low side, and the stated range ends below it.
By their numbers in this assay, from the lowest: compound 3; then compounds 2 and 1 (each within the scatter of the next); then compound 4.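

Within the data shown here, at this amine nitrogen, the read-out in this assay can move much further than the earlier compounds showed: replacing the group of 8 heavy atoms with the small sulfur-bearing group of 4 heavy atoms gives a number 60.8 percentage points higher from compound 3 to compound 4 (beyond the scatter). Sulfur alone does not account for the result, as compound 2 also carries sulfur, in a group of 9 heavy atoms with a six-membered aromatic ring, and the step is still a number 48.7 percentage points higher from compound 2 to compound 4 (beyond the scatter); the step of a number 39.5 percentage points higher from compound 1 to compound 4 (beyond the scatter) is also large, but it is read at a saturated chain carbon and so takes in the chain as well as the tail group. No supporting measurement explains why the small group does so much better here.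

Going by these compounds, it remains open whether the sulfur atom matters within the small group, which a urea with oxygen in its place would test, and whether an ethyl group in place of the methyl on the group's nitrogen would keep the high number. A longer chain carrying the same group would show whether the result holds beyond the chain of compound 4.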